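Methoxy on the outer phenyl ring of a benzothiazole amide

A few compounds are considered here, and "the series" means these few. Any claim that something is new, unique, unknown or untested is made for them only; others in the source may bear on it.

The measured compounds:
compound 1, `O=C(Nc1nc2ccccc2s1)c1cn(-c2ccccc2)nc1-c1ccc(Cl)cc1`: 7750 nM
compound 2, `O=C(Nc1nc2ccc(Cl)cc2s1)c1cn(-c2ccccc2)nc1-c1ccc(Cl)cc1`: 3230 nM
compound 3, `COc1ccc2nc(NC(=O)c3cn(-c4ccccc4)nc3-c3ccc(Cl)cc3)sc2c1`: 29300 nM

Three compounds sharing one amide scaffold were tested in a functional assay on PC-3 cells (Homo sapiens) for cytotoxicity, read by MTT assay, with a stated time of 72 h; a higher number here means a weaker inhibitor, a lower number a stronger inhibitor. Compound 2 differs from compound 1 in the fused ring system, by hydrogen in place of chloro on an aromatic carbon; this gives a 2.4-fold lower number from compound 1 to compound 2 (0.38 log units; beyond the scatter). Compound 3 carries a methoxy there instead, and the step from compound 1 is a 3.8-fold higher number from compound 1 to compound 3 (0.58 log units; beyond the scatter).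

The change of interest is methoxy in place of chloro. Between compound 2 and compound 3 it is methoxy in place of chloro on an aromatic carbon, and it produced a 9.1-fold higher number from compound 2 to compound 3 (0.96 log units; beyond the scatter). Compound 4, `COc1ccc(-c2nn(-c3ccccc3)cc2C(=O)Nc2nc3ccccc3s2)cc1`, is not yet measured; from compound 1 it is methoxy in place of chloro on an aromatic carbon. This is the same kind of change, not the same: in compound 3 it sits on a ring that is part of a fused or bridged system of two rings, meta to a fused ring and para to a fused ring, whereas in compound 4 it sits on a six-membered aromatic ring of carbon only, para to a large group.

Going by the values given here, with only one measured instance, and that on a different ring, the expectation for compound 4 is a weaker version of what compound 3 showed, resting on a 9.1-fold higher number from compound 2 to compound 3 (0.96 log units; beyond the scatter) as the sole guide. The expected step is a 2.3-fold higher number from compound 1 to compound 4 (0.37 log units; beyond the scatter). The estimated value for compound 4 in this assay is 18000 nM, between 7000 nM and 50000 nM.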

Compound 4, half-maximal inhibitory concentration: 6670 nM
Beside the measured number, compound 4's estimate is 2.7-fold (0.43 log units) above it, outside the stated range (below it).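

In this assay, methoxy in place of chloro on the six-membered aromatic ring of carbon only gave a 1.2-fold lower number from compound 1 to compound 4 (0.07 log units; within the scatter) and so made no readable difference at that place, where 4-chlorophenyl becomes 4-methoxyphenyl. This shows that the same kind of change does not carry a fixed size from one part of this series to another, since the large step seen on the fused ring system did not reappear on the outer ring, but it rests on a single pair for each place and does not show whether the ring bearing the group, its surroundings or the rest of the structure accounts for the gap, nor does it give any rule for the series as a whole. The two steps clearly differ: the same change on two cores in this assay, a 9.1-fold higher number (0.96 log units; beyond the scatter) from compound 2 to compound 3 and a 1.2-fold lower number (0.07 log units; within the scatter) from compound 1 to compound 4, 11-fold (1.02 log units) apart, beyond the scatter of two such steps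

The compounds shown leave open whether the flat result on the 4-chlorophenyl ring would also hold with chloro on the fused ring system, as in compound 2, where the same swap could be read against a stronger starting point. They also leave open how other groups in that same place would behave, such as a hydroxyl, an amine or a longer ether chain like ethoxy.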